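Swapping methoxy for chloro on a dibenzylidene cyclohexanone

The source may hold more compounds than are shown below. What is called first, only, known or untested is meant among the compounds shown, and "the series" means these compounds.

Measured so far in a functional assay on MDA-MB-231 cells (Homo sapiens) for cytotoxicity, read by MTT assay; on this read-out lower numbers stand for stronger inhibition and higher numbers for weaker inhibition:
compound 1 `COc1ccc(/C=C2\CCC/C(=C\c3ccccc3[N+](=O)[O-])C2=O)cc1` gives 45.1 ug/mL
compound 2 `COc1cccc(/C=C2\CCC/C(=C\c3cccc([N+](=O)[O-])c3)C2=O)c1` gives 13.2 ug/mL
compound 3 `COc1cccc(/C=C2\CCC/C(=C\c3cccc([N+](=O)[O-])c3)C2=O)c1OC` gives 5.59 ug/mL

Among these three, compound 2 holds the second highest number: compound 3 sits a step lower and compound 1 a step higher, both steps beyond the scatter. Among the compounds with values here, the one directly comparable step, a 2.4-fold lower number from compound 2 to compound 3 (0.37 log units; beyond the scatter), shows that adding a methoxy group to an aromatic carbon of compound 2 lowers the number modestly.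

Compound 4 `O=C1/C(=C/c2cccc(Cl)c2)CCC/C1=C\c1cccc([N+](=O)[O-])c1` is built from compound 2 by a different change: chloro in place of methoxy on an aromatic carbon. Within the data shown here, no measured pair here exchanges a methoxy for a chloro group, so the step from compound 2 to compound 3 bears on it only loosely, by showing that a change at this ring moves the number by a modest amount at most. There is no ground for expecting a direction, and a step within the scatter is the plainest expectation.

Compound 4 is therefore estimated at 12 ug/mL, with a likely range from 4 ug/mL to 35 ug/mL, which means an expected step of a 1.1-fold lower number from compound 2 to compound 4 (0.04 log units; within the scatter).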

Compound 4, half-maximal inhibitory concentration: 5.01 ug/mL
Compound 4: middle estimate off by 2.4-fold (0.38 log units), on the high side, within the range that was stated.
By their numbers in this assay, from the lowest: compounds 4 and 3 (each within the scatter of the next); then compound 2; then compound 1.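

In this assay, exchanging the 3-methoxyphenyl group for 3-chlorophenyl gives a 2.6-fold lower number from compound 2 to compound 4 (0.42 log units; beyond the scatter), so the methoxy group of compound 2 is not needed at this position for a lower number. Within the data shown here, the earlier step from compound 2 to compound 3 showed only that adding a methoxy group to this ring lowers the number; this new step shows that removing the methoxy group and putting chloro in its place lowers it as well. The entering chloro has one heavy atom against two in the methoxy group and no hydrogen-bond acceptor against one, but nothing measured here links either difference to the step, which therefore stands as an observation without an explanation.

The compounds shown leave open whether the number depends on chloro itself or would fall just as far with another group at this position, such as fluoro, bromo, trifluoromethyl or an amine. They also leave open whether the same exchange would give a step of similar size on a ring that carries a second substituent, as the methoxy-bearing ring of compound 3 does.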